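Ether capping of the side-chain hydroxyl in the coumarin-type series

The source may hold more compounds than are shown below. What is called first, only, known or untested is meant among the compounds shown, and "the series" means these compounds.

Three compounds of the shared core have numbers in a functional assay on HT-29 cells (Homo sapiens) for antiproliferative activity, read by sulforhodamine B assay, with a stated time of 48 h; a higher number here means a weaker inhibitor of growth, a lower number a stronger inhibitor of growth. Compound 1 `O=c1oc(CO)cc2ccccc12` gives 168 ug/mL. Compound 2 `COc1ccc2cc(CO)oc(=O)c2c1`, which carries a methoxy in place of hydrogen on an aromatic carbon, gives 80.3 ug/mL; the step of a 2.1-fold lower number from compound 1 to compound 2 (0.32 log units; beyond the scatter). Compound 3 `COc1ccc2cc(CCCO)oc(=O)c2c1`, with 2-hydroxyethyl in place of hydroxy on a saturated chain carbon bound to an aromatic carbon, gives 29.1 ug/mL; the step of a 2.8-fold lower number from compound 2 to compound 3 (0.44 log units; beyond the scatter). Compound 3 thus holds the lowest number of the three, beyond the scatter from both compound 2 and compound 1.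

Compound 4 `CCCCCOCCCc1cc2ccc(OC)cc2c(=O)o1` is not yet measured. Relative to compound 3 the change is pentyl in place of hydrogen on an oxygen on a saturated carbon, so hydroxy becomes pentyloxy on the side chain. Within the data shown here, no measured step covers capping of an oxygen; the two steps seen, a 2.1-fold lower number from compound 1 to compound 2 (0.32 log units; beyond the scatter) and a 2.8-fold lower number from compound 2 to compound 3 (0.44 log units; beyond the scatter), each add carbon to the core or chain and each lower the number modestly. By extension a modest further lowering for compound 4 is expected, with a wide range since the change differs in kind. The estimated step is a 2.4-fold lower number from compound 3 to compound 4 (0.38 log units; beyond the scatter). Compound 4 is estimated at 12 ug/mL, within 4 ug/mL to 35 ug/mL in this assay.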

Compound 4, concentration for 50% growth inhibition: 28.3 ug/mL
Estimate against measurement, compound 4: 2.4-fold (0.37 log units) below; measured number inside the range.
By their numbers in this assay, from the lowest: compounds 4 and 3 (each within the scatter of the next); then compound 2; then compound 1.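

Working in this assay, capping the side-chain oxygen gives a 1.0-fold lower number from compound 3 to compound 4 (0.01 log units; within the scatter) as its full effect, so hydroxy and pentyloxy read alike at this position, and a free hydroxy on the chain end is not required for the level held by compound 3. The earlier steps shown here, a 2.1-fold lower number from compound 1 to compound 2 (0.32 log units; beyond the scatter) and a 2.8-fold lower number from compound 2 to compound 3 (0.44 log units; beyond the scatter) in turn, each added carbon and each moved the number beyond the scatter, whereas compound 4 goes against any reading that added carbon alone lowers the number, even with the pentyl bringing 5 carbons at once. No measured data at hand account for this flat step at the capped oxygen.

Still open, on these data alone, is whether a smaller cap such as methyl, a longer chain on the same oxygen, or a terminal amine or carboxylic acid in place of the pentyl would leave the number equally unmoved. Also open, as far as these compounds go, is whether pentyloxy would read the same on the shorter side chain of compound 2, where the oxygen sits closer to the shared core.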